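Amide nitrogen substitution in the carbamoyl series: compound 4

The source may hold more compounds than are shown below. What is called first, only, known or untested is meant among the compounds shown, and "the series" means these compounds.

The series shares one core and varies a single aromatic position: a 2-methylphenyl in compound 1 `COc1ccc(Cl)cc1S(=O)(=O)Nc1cncc(-c2ccccc2C)c1`, a 4-chlorophenyl in compound 2 `COc1ccc(Cl)cc1S(=O)(=O)Nc1cncc(-c2ccc(Cl)cc2)c1` and a carbamoyl in compound 3 `COc1ccc(Cl)cc1S(=O)(=O)Nc1cncc(C(N)=O)c1`. In an assay on isolated protein for inhibition of alkaline phosphatase, tissue-nonspecific isozyme (Homo sapiens) (a lower number here means a stronger inhibitor, a higher number a weaker inhibitor), compound 1 gives 178 nM, compound 2 gives 198 nM and compound 3 gives 16 nM. Compound 3 therefore holds the lowest of the three numbers, with an 11-fold lower number from compound 1 to compound 3 (1.05 log units; beyond the scatter) and a 12-fold lower number from compound 2 to compound 3 (1.09 log units; beyond the scatter), whereas a 1.1-fold higher number from compound 1 to compound 2 (0.05 log units; within the scatter).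

Compound 4 `COc1ccc(Cl)cc1S(=O)(=O)Nc1cncc(C(=O)N2CCN(C)CC2)c1` keeps the carbonyl of compound 3 and alters only its nitrogen: 4-methylpiperazin-1-yl in place of amino on a carbonyl carbon. For the measured compounds named here, no measured step touches this part of the molecule. The two large steps into compound 3 exchange an aryl group for the whole carbamoyl, so they show that the carbamoyl is the favourable group here but say nothing about what happens when its amino, with its hydrogen-bond donor, is replaced by a 4-methylpiperazin-1-yl. In the absence of a direct precedent, a modest weakening is expected for compound 4 in this assay, giving an expected step of a 2.5-fold higher number from compound 3 to compound 4 (0.40 log units; beyond the scatter). Compound 4 is estimated at 40 nM, with a range from 12 nM to 150 nM.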

Compound 4, half-maximal inhibitory concentration: 671 nM
For compound 4 the middle estimate is 17-fold (1.22 log units) below the measured one; the measured number lies above the stated range.
By their numbers in this assay, from the lowest: compound 3; then compounds 1 and 2 (each within the scatter of the next); then compound 4.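

The carbamoyl advantage does not belong to the carbonyl alone: with the carbonyl kept, 4-methylpiperazin-1-yl in place of amino gives (a 42-fold higher number from compound 3 to compound 4 (1.62 log units; beyond the scatter)) in this assay, so this position responds strongly to what sits on the carbonyl carbon. The substituted amide also falls behind both aryl groups, with (a 3.4-fold higher number from compound 2 to compound 4 (0.53 log units; beyond the scatter)) and (a 3.8-fold higher number from compound 1 to compound 4 (0.58 log units; beyond the scatter)), so a carbonyl at this aromatic carbon can give either the lowest number in the series, in compound 3, or the highest, in compound 4. Nothing available gives a measured reason for this loss.

Compound 4 loses the hydrogen-bond donor of the amino group and gains a six-membered ring with a second nitrogen in one change, so the compounds shown cannot assign the loss to any one of these differences. Methylamino and dimethylamino on the same carbonyl carbon, or morpholin-4-yl and piperidin-1-yl in place of 4-methylpiperazin-1-yl, would separate these contributions, and a carboxylic acid in place of the carbamoyl would test how much of the carbamoyl is needed at all.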